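A few compounds are considered here, and "the series" means these few. Any claim that something is new, unique, unknown or untested is made for them only; others in the source may bear on it.

Working notes on the series. Compound 1 `COc1ncc(-c2ccc3ncnc(Nc4cnn(CCCO)c4)c3c2)cc1NS(C)(=O)=O` gives 1420 nM in a functional assay on HCT-116 cells (Homo sapiens) for antiproliferative activity, read by sulforhodamine B assay, with a stated time of 72 h; a higher number here means a weaker inhibitor, a lower number a stronger inhibitor. Compound 2 `CCCCS(=O)(=O)Nc1cc(-c2ccc3ncnc(Nc4ccc(OCCO)nc4)c3c2)cnc1OC` in this assay returns only a limit, > 20000 nM. Going by the values given here, compound 2 thus sits at the limit (the limit of > 20000 nM in this assay, at which 1 of the 2 values shown sits), and its true position is known only as a bound; the two measured compounds differ in more than one place, so they form no single-change pair. Compound 3 `COc1ncc(-c2ccc3ncnc(Nc4ccc(OCCO)nc4)c3c2)cc1NS(=O)(=O)c1ccc(F)cc1F` is the next compound to be measured in this assay. It differs from compound 2 by 2,4-difluorophenyl in place of butyl on a sulfonyl sulfur, that is, butylsulfonyl to (2,4-difluorophenyl)sulfonyl on the sulfonamide nitrogen. With only a limit for compound 2, the size of this step cannot be anchored on a measured pair. The step from compound 2 to compound 3 is expected to be an at least 2.5-fold lower number from compound 2 to compound 3 (0.39 log units; beyond the scatter), toward stronger inhibition, though it may fall within scatter. Compound 3 is expected to give 8000 nM in this assay, within 2000 nM to 20000 nM.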

Compound 3, half-maximal inhibitory concentration: 2340 nM
Estimate against measurement, compound 3: 3.4-fold (0.53 log units) above, within the range that was stated.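

Moving from butyl to 2,4-difluorophenyl on a sulfonyl sulfur gives an at least 8.5-fold lower number from compound 2 to compound 3 (0.93 log units; beyond the scatter) in this assay, the first single-change reading in the series, and it shows that the group at this position can shift antiproliferative activity beyond the scatter. For compound 2, the value > 20000 nM is a limit of the assay and not a number. The step therefore gives only a bound on the size of the change, not its full measure: the limit of > 20000 nM in this assay, at which 1 of the 3 values shown sits.

On these data alone, whether the change follows from the aromatic ring itself or from its two fluorine atoms stays open, and a plain phenyl on this sulfonyl sulfur would separate the two. Compound 1 differs from compound 3 in more than one place, so the effect of a methyl at this position also remains unresolved.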